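This account rests on a few compounds, and the source may have more. Where it says the series, first, only, none or still open, it means among the compounds named here.

Of the compounds shown here, two with a shared core have been measured, and a third awaits testing. Compound 1 `Cc1cc(CN(CC2CC2)C(CC(=O)O)c2ccc(Cl)cc2)ccc1OCCn1c(=O)ccn(C)c1=O` and compound 2 `CCCN(Cc1ccc(OCCn2c(=O)ccn(C)c2=O)c(OC)c1)C(CC(=O)O)c1ccc(Cl)cc1` were both examined in an assay on CHO cells for displacement of a labelled ligand from C-X-C chemokine receptor type 3 (Homo sapiens), with a stated time of 60 min; on this read-out higher numbers stand for weaker inhibition and lower numbers for stronger inhibition. In this assay compound 1 gives 91 nM, and compound 2 gives 132 nM. These two numbers are not separated beyond the usual scatter, so neither compound can be called stronger or weaker than the other on this evidence.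

Compound 3 `COc1cc(CN(CC2CC2)C(CC(=O)O)c2ccc(Cl)cc2)ccc1OCCn1c(=O)ccn(C)c1=O` has not yet been measured. It differs from compound 2 in one place: cyclopropyl in place of ethyl on a saturated chain carbon bound to an amine nitrogen. In the words of the count, this is cyclopropyl in place of ethyl on a saturated chain carbon bound to an amine nitrogen. Within the data shown here, no measured pair shows this exact change alone, so there is nothing to lean on beyond the two numbers already given. The expectation is therefore a step of little size in this assay, with no direction beyond the scatter, as a 1.3-fold lower number from compound 2 to compound 3 (0.12 log units; within the scatter) expresses. Compound 3 is estimated at 100 nM, with a range from 40 nM to 250 nM.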

Compound 3, half-maximal inhibitory concentration: 91 nM
The estimate for compound 3 lay 1.1-fold (0.04 log units) above the measured number, within the range that was stated.
By their numbers in this assay, from the lowest: compounds 1, 3 and 2 (each within the scatter of the next).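

In this assay, cyclopropyl in place of ethyl on a saturated chain carbon bound to an amine nitrogen gives a 1.5-fold lower number from compound 2 to compound 3 (0.16 log units; within the scatter) and so can now be read alone, which compounds 1 and 2 could not offer, since they differ in two places at once. Methoxy in place of methyl on an aromatic carbon, a second single change, gives no change at the digits printed from compound 1 to compound 3 (within the scatter) in the same assay. Each of these two changes therefore leaves the number where repeated measurements alone could have put it, and no supporting measurement speaks to why these steps are so small.

What the compounds shown leave open is how far the chain carbon bound to the amine nitrogen can be built out, for example with a butyl chain or a benzyl group in place of cyclopropyl, before the number moves beyond the scatter. The same question stands for the aromatic carbon, where chlorine or an ethoxy group could show whether any group there separates from methyl and methoxy.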